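This account rests on a few compounds, and the source may have more. Where it says the series, first, only, none or still open, it means among the compounds named here.

Three compounds share one core. Compound 1 `NC(=O)c1cc2c(Cc3ccccc3)n[nH]c2cc1O` gives "not determined" (no result reported) in a functional assay on A2780 cells (Homo sapiens) for antiproliferative activity, read by resazurin assay, with a stated time of 72 h; a lower number here means a stronger inhibitor, a higher number a weaker inhibitor. Compound 2 `CN(Cc1cccc(F)c1)C(=O)c1cc2c(Cc3ccccc3)n[nH]c2cc1O` gives 5000 nM there, and compound 3 `Cc1ccc(CN(C)C(=O)c2cc3c(Cc4ccccc4)n[nH]c3cc2O)cc1` gives 6900 nM. Among the compounds with values here, the single step between measured compounds, a 1.4-fold higher number from compound 2 to compound 3 (0.14 log units; within the scatter), exchanges one ring for another on a saturated chain carbon bound to an amide-type nitrogen and stays within the scatter. Compound 2 thus holds the lowest of the two numbers, with compound 3 within the scatter of it, and compound 1 offering no number to compare.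

Compound 4 `CCOc1ccc(CN(C)C(=O)c2cc3c(Cc4ccccc4)n[nH]c3cc2O)cc1` differs from compound 2 at the same carbon: 4-ethoxyphenyl in place of 3-fluorophenyl on a saturated chain carbon bound to an amide-type nitrogen. Within the data shown here, the only step that bears on this is the one already described, which swapped the ring on that carbon and moved the number little. With so little evidence, and that evidence pointing to small movement, the expectation is that putting 4-ethoxyphenyl in place of 3-fluorophenyl will likewise not shift the number beyond the scatter, perhaps nudging it slightly upward as the earlier swap did, the expected step being a 1.2-fold higher number from compound 2 to compound 4 (0.08 log units; within the scatter). Compound 4 is therefore estimated to give about 6000 nM, with a plausible range from 2500 nM to 15000 nM.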

Compound 4, half-maximal inhibitory concentration: 3200 nM
Compound 4: middle estimate off by 1.9-fold (0.27 log units), on the high side; the range from low to high includes it.
By their numbers in this assay, from the lowest: compounds 4, 2 and 3 (each within the scatter of the next, the first and the last beyond it).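

In this assay, the step of a 1.6-fold lower number from compound 2 to compound 4 (0.19 log units; within the scatter) stays within the scatter, so the ring on this saturated chain carbon can carry an ethoxy group, with its added oxygen and hydrogen-bond acceptor, without a clear loss of activity. The comparison with compound 3 adds something the first ring swap did not show: the step of a 2.2-fold lower number from compound 3 to compound 4 (0.33 log units; beyond the scatter) is a modest one beyond the scatter, and it comes from changing only the group on an aromatic carbon of that ring, from methyl to ethoxy. Nothing measured here explains why this exchange moves the number.

The step from compound 2 to compound 4 changes both the group and where it sits on the ring, so a 3-ethoxyphenyl or 4-fluorophenyl group would be needed to separate those two changes. The compounds shown also leave open whether a longer chain such as butoxy, or an amine or a carboxylic acid on the same ring, would continue the small gain seen with ethoxy over methyl.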